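Bromo in place of methoxy: compound 3 to compound 4

The source may report more compounds than this note shows. Statements on the series, on what has been measured and on what is new or still open speak of the compounds shown alone.

Measured in a functional assay on MCF7 cells (Homo sapiens) for antiproliferative activity, read by MTT assay, with a stated time of 48 h; on this read-out lower numbers stand for stronger inhibition and higher numbers for weaker inhibition:
- compound 1 `O=C(/C=C/c1ccc(Br)cc1)Nc1cc(-c2ccc(Br)cc2)[nH]n1` gives 920 nM
- compound 2 `O=C(/C=C/c1ccc(Br)cc1)Nc1cc(-c2ccccc2)[nH]n1` gives 1240 nM
- compound 3 `COc1ccc(/C=C/C(=O)Nc2cc(-c3ccc(C)cc3)[nH]n2)cc1` gives 860 nM

All three values lie within the scatter of one another, so compound 3 stands level with compound 1 and compound 2 in this assay and no order can be read from them. Compound 4 `Cc1ccc(-c2cc(NC(=O)/C=C/c3ccc(Br)cc3)n[nH]2)cc1` is compound 3 with bromo in place of methoxy on an aromatic carbon, para to a large group (bromo in place of methoxy on an aromatic carbon). Among the measured compounds shown here, the one measured step is hydrogen in place of bromo on an aromatic carbon (a 1.3-fold higher number from compound 1 to compound 2 (0.13 log units; within the scatter)) and it lies within the scatter. That step concerns a different ring from the one changed here, so it bears only indirectly. For the measured compounds named here, no measured step covers 4-methoxyphenyl to 4-bromophenyl. The 4-bromophenyl group is already present in compound 1 (920 nM) and compound 2 (1240 nM), and both values lie within the scatter of compound 3 (860 nM). The expected step (a 1.2-fold higher number from compound 3 to compound 4 (0.07 log units; within the scatter)) therefore stays within the scatter. Compound 4 is estimated at 1000 nM (expected range 550 nM to 1800 nM).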

Compound 4, half-maximal inhibitory concentration: 1370 nM
Beside the measured number, compound 4's estimate is 1.4-fold (0.14 log units) below it, within the range that was stated.
By their numbers in this assay, from the lowest: compounds 3, 1, 2 and 4 (each within the scatter of the next).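

In this assay, the first direct test of this position gives a 1.6-fold higher number from compound 3 to compound 4 (0.20 log units; within the scatter), so 4-methoxyphenyl and 4-bromophenyl cannot be told apart here, at least with methyl on the other aromatic ring. Compound 4 also extends the comparison on that other ring: a 1.1-fold higher number from compound 2 to compound 4 (0.04 log units; within the scatter) and a 1.5-fold higher number from compound 1 to compound 4 (0.17 log units; within the scatter), so hydrogen, bromo and methyl there all remain within the scatter of one another when 4-bromophenyl is held constant. No supporting evidence is available to explain these small steps.

The compounds shown leave open whether an amine or a carboxylic acid at this position would give a step beyond the scatter. Also open, on these data alone, is whether bromo in place of methoxy reads the same with hydrogen or bromo, rather than methyl, on the other ring.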